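The compounds below may be only part of what the source reports. "The series", "measured", "known", "first", "only" and "open" are said of these compounds alone.

Compound 1 `COc1ccc(-c2cc3ccccc3nc2/C=C/C(=O)c2ccc(O)cc2)cc1` — 6710 nM
Compound 2 `COc1ccc(-c2cc3ccccc3nc2/C=C/C(=O)c2ccc([N+](=O)[O-])cc2)cc1` — 4110 nM

Both were read in a functional assay on MCF7 cells (Homo sapiens) for antiproliferative activity, read by XTT assay, with a stated time of 72 h; on this read-out higher numbers stand for weaker inhibition and lower numbers for stronger inhibition. Compound 2 holds the lower of the two numbers in this assay, yet the step of a 1.6-fold lower number from compound 1 to compound 2 (0.21 log units; within the scatter) is within the scatter, so compound 2 and compound 1 cannot be separated on this read-out. Compound 3 `COc1ccc(-c2cc3ccccc3nc2/C=C/C(=O)c2ccco2)cc1` is not yet measured. It differs from compound 2 as furan-2-yl in place of 4-nitrophenyl on a carbonyl carbon. Among the compounds with values here, the only measured step, a 1.6-fold lower number from compound 1 to compound 2 (0.21 log units; within the scatter), concerns a different exchange on the group that leaves here and was within the scatter; no measured pair exchanges the whole group on the carbonyl carbon, so the data give no direct guide for this change. With a single, flat step in hand, no step beyond the scatter is expected in this assay for compound 3, the estimated step being a 1.1-fold higher number from compound 2 to compound 3 (0.04 log units; within the scatter), with a wide range to allow for the unknown. Compound 3 is thus expected to give about 4500 nM in this assay, between 1500 nM and 13000 nM.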

Compound 3, half-maximal inhibitory concentration: 710 nM
Estimate against measurement, compound 3: 6.3-fold (0.80 log units) above, outside the stated range (below it).
By their numbers in this assay, from the lowest: compound 3; then compounds 2 and 1 (each within the scatter of the next).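

In this assay, the group on the carbonyl carbon clearly moves the read-out: furan-2-yl in place of 4-nitrophenyl gives a 5.8-fold lower number from compound 2 to compound 3 (0.76 log units; beyond the scatter), and furan-2-yl in place of 4-hydroxyphenyl gives a 9.5-fold lower number from compound 1 to compound 3 (0.98 log units; beyond the scatter). The earlier exchange of hydroxy for nitro on the aromatic carbon left compound 1 and compound 2 inseparable, so this position responds to replacement of the whole group, even though that substituent exchange on the phenyl ring showed no step beyond the scatter, and compound 3 is the strongest inhibitor of the three, with both of its steps beyond the scatter. No evidence is available on what lies behind this step.

These three compounds do not tell whether the step follows from the hetero atom of the furan-2-yl group, from the five-membered aromatic ring, or simply from the departure of a substituted six-membered aromatic ring. A thiophen-2-yl group or an unsubstituted phenyl on the same carbonyl carbon would help to separate these readings.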